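A difluorophenyl swap among three closely matched sulfonamides

The source may report more compounds than this note shows. Statements on the series, on what has been measured and on what is new or still open speak of the compounds shown alone.

In a functional assay on cells (leukaemia cell line, Homo sapiens) for inhibition, read by sulforhodamine B assay, with a stated time of 48 h (a higher number here means a weaker inhibitor of growth, a lower number a stronger inhibitor of growth), compound 1 `O=S(=O)(Nc1ccc(F)c(Cl)c1)c1ccc(-c2cnc(C3CC3)o2)cc1` gives 260 nM, compound 2 `O=S(=O)(Nc1cccc(Cl)c1)c1ccc(-c2cnc(C3CC3)o2)cc1` gives 477 nM and compound 3 `O=S(=O)(Nc1ccc(Br)c(Cl)c1)c1ccc(-c2cnc(C3CC3)o2)cc1` gives 491 nM. All three gaps lie within the scatter, so compound 3 cannot be ranked against the other two.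

Compound 4 `O=S(=O)(Nc1cc(F)cc(F)c1)c1ccc(-c2cnc(C3CC3)o2)cc1` changes the group on the sulfonamide nitrogen: 3,5-difluorophenyl in place of 4-bromo-3-chlorophenyl on a sulfonamide nitrogen. In words, this places 3,5-difluorophenyl in place of 4-bromo-3-chlorophenyl on a sulfonamide nitrogen.

Among the measured compounds shown here, three measured steps bear on this change: a 1.8-fold higher number from compound 1 to compound 2 (0.26 log units; within the scatter), a 1.9-fold higher number from compound 1 to compound 3 (0.28 log units; within the scatter) and a 1.0-fold higher number from compound 2 to compound 3 (0.01 log units; within the scatter). Each exchanges one substituent on the phenyl group, and each stays within the scatter. For the measured compounds named here, all three measured compounds keep their chloro group, so no measured step shows what removing it does. No shift beyond the scatter is expected, but the uncertainty is wider than those steps suggest. The estimated change is a 1.2-fold lower number from compound 3 to compound 4 (0.09 log units; within the scatter). For compound 4 the expected value is 400 nM, with an estimated range of 170 nM to 950 nM.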

Compound 4, concentration for 50% growth inhibition: 2140 nM
Beside the measured number, compound 4's estimate is 5.4-fold (0.73 log units) below it; the whole stated range lies below it.
By their numbers in this assay, from the lowest: compounds 1, 2 and 3 (each within the scatter of the next); then compound 4.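

In this assay, the group on the sulfonamide nitrogen proves able to shift the result: bringing in 3,5-difluorophenyl gives a 4.4-fold higher number from compound 3 to compound 4 (0.64 log units; beyond the scatter) and, measured from the other two compounds, a 4.5-fold higher number from compound 2 to compound 4 (0.65 log units; beyond the scatter) and an 8.2-fold higher number from compound 1 to compound 4 (0.92 log units; beyond the scatter) as well. Unlike the earlier exchanges, which all kept the chloro group and stayed within the scatter, these three steps remove it, add two fluoro groups and go beyond the scatter, so this position tolerates less than compounds 1, 2 and 3 alone suggested. Nothing shown gives a reason for this weaker growth inhibition.

The compounds shown do not separate the loss of the chloro group from the arrival of the two fluoro groups. From the compounds shown here alone, it also remains open how a methyl group, a methoxy group or an amine on this phenyl group would compare.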